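A few compounds are considered here, and "the series" means these few. Any claim that something is new, unique, unknown or untested is made for them only; others in the source may bear on it.

In an ADME assay on microsomes from liver (Rattus norvegicus) for metabolic stability, with a stated time of 10 min (a higher number here means that more of the compound is left, a lower number that less of the compound is left), compound 2 `COc1nn2cc(-c3cc4ccccc4o3)nc2s1` gives 31%. Compound 1 `CCSc1nn2cc(-c3cc4ccccc4o3)nc2s1` gives 35%, within the scatter of compound 2, while compound 3 `COc1nn2cc(-c3cc4c(OC)cccc4o3)nc2s1` gives 42%. Compound 4 `c1ccc2oc(-c3cn4nc(C5CC5)sc4n3)cc2c1` differs from compound 2 as follows: cyclopropyl in place of methoxy on an aromatic carbon. Among the measured compounds shown here, two measured steps bear on this change. The one at the same place, where methoxy replaced ethylsulfanyl, is a number 4 percentage points lower from compound 1 to compound 2 (within the scatter), and it stays within the scatter. The other, a number 11 percentage points higher from compound 2 to compound 3 (beyond the scatter), is modest and lies at a different place. No step beyond the scatter is therefore expected here. The expected change is a number 2 percentage points higher from compound 2 to compound 4 (within the scatter). For compound 4 the estimated value is 33%, with an expected range from 18% to 50%.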

Compound 4, percent of the compound remaining: 53%
Beside the measured number, compound 4's estimate is 20 percentage points below it; measured number outside the range, above it.
By their numbers in this assay, from the lowest: compounds 2, 1 and 3 (each within the scatter of the next, the first and the last beyond it); then compound 4.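

In this assay, this position proved able to move the read-out beyond the scatter: cyclopropyl in place of methoxy gives a number 22 percentage points higher from compound 2 to compound 4 (beyond the scatter), and cyclopropyl in place of ethylsulfanyl gives a number 18 percentage points higher from compound 1 to compound 4 (beyond the scatter). The earlier exchange at this place, a number 4 percentage points lower from compound 1 to compound 2 (within the scatter), had shown no such step. Nothing among the data shown accounts for the rise. Going by these compounds, whether it depends on the three-membered ring remains open, as an isopropyl chain, a cyclobutyl ring or an amine at this place would show. Also open, on these data alone, is whether cyclopropyl gives a similar step with the added methoxy of compound 3.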